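This account rests on a few compounds, and the source may have more. Where it says the series, first, only, none or still open, it means among the compounds named here.

Measured so far in an ADME assay on CEM-SS cells (Homo sapiens) for cytotoxicity, read by XTT assay, with a stated time of 6 days; on this read-out lower numbers stand for higher toxicity in this test and higher numbers for lower toxicity in this test:
Compound 1 `CCCC(=O)OCSc1ccccc1C(=O)NCCCCCC(N)=O` gives 16.3 uM
Compound 2 `CCCC(=O)OCSc1ccccc1C(=O)NCC(=O)N(C)C` gives 38.3 uM
Compound 3 `CCCC(=O)OCSc1ccccc1C(=O)NCC(=O)NCC(=O)OC` is not yet measured.

Among the measured compounds shown here, compound 2 stands higher of the two numbers; the only known step, a 2.3-fold higher number from compound 1 to compound 2 (0.37 log units; beyond the scatter), also alters the group on the amide-type nitrogen of the shared core. Compound 3 differs from compound 2 by ((methoxycarbonyl)methyl)amino in place of dimethylamino on a carbonyl carbon. For the measured compounds named here, no measured step exchanges dimethylamino, so that single step gives no direction, and a change within the scatter is expected: a 1.3-fold lower number from compound 2 to compound 3 (0.11 log units; within the scatter). Compound 3 is therefore estimated at 30 uM, with a range of 12 uM to 75 uM.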

Compound 3, half-maximal toxic concentration: > 100 uM
Compound 3 ended at the assay's limit; the forecaster's own chance of this, stated with the estimate: 10%; middle value at least 3.3-fold (0.52 log units) from the limit.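

In this assay, compound 3 reads as a limit and not a number: the limit of > 100 uM in this assay, at which 1 of the 3 values shown sits.

On the carbonyl carbon, ((methoxycarbonyl)methyl)amino in place of dimethylamino gives an at least 2.6-fold higher number from compound 2 to compound 3 (0.41 log units; beyond the scatter), which shows that this place can move the read-out toward lower toxicity in this test. The wider exchange on the saturated chain carbon bound to an amide-type nitrogen gives an at least 6.1-fold higher number from compound 1 to compound 3 (0.78 log units; beyond the scatter), and both steps are bounded on one side only.

On these data alone, their full size remains open. So does how a carboxylic acid or a plain methylamino group on this carbonyl carbon would read.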